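The compounds below may be only part of what the source reports. "The series", "measured", "known", "first", "only" and "open" are said of these compounds alone.

Compound 1 `CC[C@](C)(O)CC(=O)O[C@H](CC=C(C)C)C1=CC(=O)c2c(O)ccc(O)c2C1=O` is measured in a functional assay on HeLa cells (Homo sapiens) for cytotoxicity, read by MTT assay (on this read-out lower numbers stand for stronger inhibition and higher numbers for weaker inhibition), at 30200 nM, the lowest of the three numbers recorded, though every gap to the others is within the scatter. Compound 2 `CCCC(CC(=O)O[C@H](CC=C(C)C)C1=CC(=O)c2c(O)ccc(O)c2C1=O)OC(C)=O` gives 51200 nM in this assay, and compound 3 `CC(C)=CC[C@@H](OC(=O)CC(O)c1ccccc1)C1=CC(=O)c2c(O)ccc(O)c2C1=O` gives 44500 nM. The steps of a 1.7-fold higher number from compound 1 to compound 2 (0.23 log units; within the scatter), a 1.5-fold higher number from compound 1 to compound 3 (0.17 log units; within the scatter) and a 1.2-fold lower number from compound 2 to compound 3 (0.06 log units; within the scatter) all swap the group on the saturated chain carbon bound to the carbonyl carbon, and none leaves the scatter. Compound 4 `CCC(CO[C@H](CC=C(C)C)C1=CC(=O)c2c(O)ccc(O)c2C1=O)OC` differs from compound 1 by 2-methoxybutyl in place of (2-hydroxy-2-methylbutyl)carbonyl on an oxygen on a saturated carbon; the carbonyl itself departs and an ether remains. Among the compounds with values here, no measured step probes that change, so the expectation for compound 4 rests on the flat pattern: it is expected to give a 1.3-fold higher number from compound 1 to compound 4 (0.10 log units; within the scatter). Compound 4 is therefore estimated at 38000 nM, between 15000 nM and 95000 nM.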

Compound 4, half-maximal inhibitory concentration: 63500 nM
Beside the measured number, compound 4's estimate is 1.7-fold (0.22 log units) below it; the range from low to high includes it.
By their numbers in this assay, from the lowest: compounds 1, 3, 2 and 4 (each within the scatter of the next, the first and the last beyond it).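

In this assay, replacing (2-hydroxy-2-methylbutyl)carbonyl with 2-methoxybutyl gives a 2.1-fold higher number from compound 1 to compound 4 (0.32 log units; beyond the scatter), the only step shown that leaves the scatter, and a modest one. The change thus registers where the swaps of groups on the saturated chain carbon did not, although compound 4 remains within the scatter of compound 2. No evidence is available that explains this step. On these data alone, the change removes the carbonyl and the hydroxy together, so their separate contributions remain open. Also open, as far as these compounds go, is how an amine or a longer chain would behave in this place.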